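The compounds below may be only part of what the source reports. "The series", "measured", "known", "first", "only" and "open" are said of these compounds alone.

For the measured compounds named here, compound 1 `O=[N+]([O-])c1ccc(S(=O)(=O)N2CC(n3cnc4ncnc(O)c43)OCc3ccccc32)cc1` and compound 2 `COC(CN(c1ccccc1CO)S(=O)(=O)c1ccccc1N)n1cc(F)c(=O)[nH]c1=O` are the only compounds measured so far in a functional assay on MCF7 cells (Homo sapiens) for antiproliferative activity; a lower number here means a stronger inhibitor, a higher number a weaker inhibitor. In this assay compound 1 gives only a limit of the assay, > 100000 nM. Compound 2 likewise gives only a limit, > 100000 nM. Going by the values given here, both readings sit at the same point, (the limit of > 100000 nM in this assay, at which 2 of the 2 values shown sit), so no step between measured compounds can be read from them. Compound 3 `O=[N+]([O-])c1ccccc1S(=O)(=O)N1CC(n2cnc3ncnc(O)c32)OCc2ccccc21` has not been measured; it carries 2-nitrophenyl in place of 4-nitrophenyl on a sulfonyl sulfur. From this change no shift beyond the scatter is expected, so the step of a number no higher from compound 1 to compound 3 (the limit leaves the size open) is estimated as none. Compound 3 is expected to give 100000 nM, within 30000 nM to 300000 nM, most likely again only as a limit.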

Compound 3, half-maximal inhibitory concentration: 19700 nM
Estimate against measurement, compound 3: 5.1-fold (0.71 log units) above; the whole stated range lies above it.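

In this assay, 2-nitrophenyl in place of 4-nitrophenyl on a sulfonyl sulfur gives an at least 5.0-fold lower number from compound 1 to compound 3 (0.70 log units; beyond the scatter). The two groups have the same atoms, so this position responds to how the group is joined, not only to which atoms it holds. Compound 3, at 19700 nM, is the only compound shown with a number rather than a limit: the limit of > 100000 nM in this assay, at which 2 of the 3 values shown sit.

Going by these compounds, the true size of the step stays open, as the reading for compound 1 is only a limit. On these data alone, whether a nitrile in place of the nitro group on the 2-nitrophenyl would give a similar reading is also open.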